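Carbonyl substituent series on the shared core

The source may report more compounds than this note shows. Statements on the series, on what has been measured and on what is new or still open speak of the compounds shown alone.

Measured so far in an assay on HEK293 cells for displacement of a labelled ligand from Melanocortin receptor 4 (Homo sapiens); a lower number here means a stronger inhibitor, a higher number a weaker inhibitor:
compound 1 `CC(C)C[C@H](N)c1cc(C(F)(F)F)ccc1N1CCN(C(=O)CCC(N)=O)CC1`: > 10000 nM, a limit of the assay
compound 2 `Cc1ccc(OCC(=O)N2CCN(c3ccc(C(F)(F)F)cc3[C@@H](N)CC(C)C)CC2)cc1`: 4400 nM
compound 3 `CC(C)C[C@H](N)c1cc(C(F)(F)F)ccc1N1CCN(C(=O)C(C)Cc2ccc(Cl)cc2O)CC1`: 36 nM

Compound 3 holds the lowest of the two numbers; the nearest number is that of compound 2, separated by a 120-fold lower number from compound 2 to compound 3 (2.09 log units; beyond the scatter). Compound 1 sits at the limit of > 10000 nM in this assay, at which 1 of the 3 values shown sits.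

Compound 4 `CC(C)C[C@H](N)c1cc(C(F)(F)F)ccc1N1CCN(C(=O)CCC(=O)N(C)C)CC1` differs from compound 3 in one place: 2-(dimethylcarbamoyl)ethyl in place of 1-(4-chloro-2-hydroxybenzyl)ethyl on a carbonyl carbon. The entering 2-(dimethylcarbamoyl)ethyl group is closest to the 2-carbamoylethyl group of compound 1, so the step that bears most is an at least 270-fold lower number from compound 1 to compound 3 (2.44 log units; beyond the scatter), a large one, and the step from compound 3 to compound 4 is expected to run the other way with a size near it, a 330-fold higher number from compound 3 to compound 4 (2.52 log units; beyond the scatter). The step of an at least 2.2-fold lower number from compound 1 to compound 2 (0.35 log units; beyond the scatter) adds that even the 4-methylphenoxy group already moved off the limit. Compound 4 is expected at 12000 nM, within 2500 nM to 60000 nM, with a good chance that only a limit is reported.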

Compound 4, inhibition constant: > 10000 nM
Compound 4: only a limit was reported; the forecaster's own chance of this, stated with the estimate: 65%; the middle value lies beyond the limit too.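

In this assay compound 4 gives > 10000 nM, which is a limit and not a number. Swapping the groups on the carbonyl carbon gives an at least 270-fold higher number from compound 3 to compound 4 (2.44 log units; beyond the scatter), and (dimethylcarbamoyl)methyl in place of 4-methylphenoxy gives an at least 2.2-fold higher number from compound 2 to compound 4 (0.35 log units; beyond the scatter). The step between the two amides cannot be read, so dimethylamino in place of amino shows no readable change, and both stay at the limit: the limit of > 10000 nM in this assay, at which 2 of the 4 values shown sit.

Open, on these data alone, is which part of the 1-(4-chloro-2-hydroxybenzyl)ethyl group carries the gain of compound 3. A 1-benzylethyl group, without hydroxy or chlorine, would separate the ring from its substituents, and a carboxylic acid at the chain end would extend the 2-carbamoylethyl line.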